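Trimming an Allyl Ether Down to a Methyl Ether

The compounds below may be only part of what the source reports. "The series", "measured", "known", "first", "only" and "open" are said of these compounds alone.

Compound 1, `COCc1ccccc1Cc1cnc(N)nc1N`, gives 39800 nM in an assay for inhibition of Dihydrofolate reductase (Gallus gallus); a higher number here means a weaker inhibitor, a lower number a stronger inhibitor.
Compound 2, `C=CCOc1ccccc1Cc1cnc(N)nc1N`, gives 21400 nM in this assay.

Among the compounds with values here, compound 2 holds the lower of the two numbers measured so far, but its only neighbour is compound 1, and the step of a 1.9-fold lower number from compound 1 to compound 2 (0.27 log units; within the scatter) is within the scatter, so the two compounds cannot be told apart on these data. Compound 3, `COc1ccccc1Cc1cnc(N)nc1N`, keeps the shared core and the oxygen on the aromatic ring and shortens the chain on that oxygen: hydrogen in place of vinyl on a saturated chain carbon bound to an oxygen on an aromatic ring. Within the data shown here, the single measured step compares methoxymethyl with allyloxy, a different exchange from allyloxy to methoxy, so it speaks to this change only loosely; what it does show is that a change of similar size at the same position stayed within the scatter. Among the measured compounds shown here, with no closer precedent, the expectation for this assay is a small step, a 1.2-fold higher number from compound 2 to compound 3 (0.07 log units; within the scatter), not beyond the scatter in either direction. Compound 3 is therefore estimated at 25000 nM, with a range from 9000 nM to 70000 nM.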

Compound 3, inhibition constant: 28800 nM
Compound 3: middle estimate off by 1.2-fold (0.06 log units), on the low side; the measured number falls inside the stated range.
By their numbers in this assay, from the lowest: compounds 2, 3 and 1 (each within the scatter of the next).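

Cutting allyloxy back to methoxy, with the oxygen kept on the aromatic ring, gives a 1.3-fold higher number from compound 2 to compound 3 (0.13 log units; within the scatter), so in this assay these data detect no effect of removing the vinyl end of the chain. Exchanging methoxymethyl for methoxy on an aromatic carbon gives a 1.4-fold lower number from compound 1 to compound 3 (0.14 log units; within the scatter), which means that all three groups at this position now lie within the scatter of one another: repeated measurements of a single compound could differ this much, and no order among the three can be claimed. No other measurement bears on this result, so the numbers stand without any explanation.

As far as these compounds go, all three groups are small ethers, so it remains open whether a group of another kind at this position, such as an amine or a carboxylic acid, would give a step beyond the scatter. The same question holds for a longer chain on the oxygen, such as butoxy, and for plain hydrogen in place of the methoxy, either of which would test whether this position can change the number at all.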